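Swapping the Thiophene Sulfonamide for a Methoxyphenyl Group

The compounds below may be only part of what the source reports. "The series", "measured", "known", "first", "only" and "open" are said of these compounds alone.

Compound 1 `Cc1ccc(S(=O)(=O)Nc2ccc(-c3nc4ccccc4o3)cc2)cc1`: in an assay on cells for inhibition of HSP60/HSP10 (Homo sapiens), with a stated time of 60 min (on this read-out lower numbers stand for stronger inhibition and higher numbers for weaker inhibition), compound 1 gives only a limit, > 100000 nM.
Compound 2 `O=S(=O)(Nc1ccc(-c2nc3ccccc3o2)cc1)c1ccccc1F`: in this assay compound 2 gives only a limit, > 100000 nM.
Compound 3 `O=S(=O)(Nc1ccc(-c2nc3ccccc3o2)cc1)c1cccs1`: in this assay compound 3 gives 63000 nM.

Compound 3 is the only one of the three with an actual number; the other two sit at the ceiling of the assay, (the limit of > 100000 nM in this assay, at which 2 of the 3 values shown sit). Compound 4 `COc1ccccc1S(=O)(=O)Nc1ccc(-c2nc3ccccc3o2)cc1` differs from compound 3 in one place: 2-methoxyphenyl in place of thiophen-2-yl on a sulfonyl sulfur. Among the measured compounds shown here, two measured steps bear on this change, each in the opposite direction: an at least 1.5-fold lower number from compound 1 to compound 3 (0.20 log units; that floor lies within the scatter) and an at least 1.5-fold lower number from compound 2 to compound 3 (0.20 log units; that floor lies within the scatter). Both of those floors lie within the scatter, so the thiophen-2-yl ring gave at best a modest gain over a six-membered carbon ring. Compound 4 returns to a six-membered carbon ring, as in compound 1 and compound 2, so a higher number, quite possibly again a limit, is expected; the estimated step is a 1.4-fold higher number from compound 3 to compound 4 (0.15 log units; within the scatter). For compound 4 in this assay the estimate is 90000 nM, between 30000 nM and 300000 nM.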

Compound 4, half-maximal inhibitory concentration: > 100000 nM
Compound 4 ended at the assay's limit; the forecaster's own chance of this, stated with the estimate: 55%; middle value at least 1.1-fold (0.04 log units) from the limit.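

In this assay, 2-methoxyphenyl in place of thiophen-2-yl on the sulfonyl sulfur gives an at least 1.5-fold higher number from compound 3 to compound 4 (0.20 log units; that floor lies within the scatter), so this change alone cannot be called a real loss. Among the compounds shown here, what compound 4 adds is a third six-membered carbon ring with a different group on it, and that ring again gives only a limit, so methoxy does no better than fluoro or the 4-methylphenyl ring and thiophen-2-yl remains the only group here with an actual number. The steps among compounds 1, 2 and 4 cannot be read, and most of this series now rests on one ceiling: the limit of > 100000 nM in this assay, at which 3 of the 4 values shown sit.

As far as these compounds go, whether thiophen-2-yl truly outperforms the six-membered rings stays open, given how little separates it from that ceiling. From the compounds shown here alone, how a furan-2-yl ring or an amine on the sulfonyl sulfur would read is also open.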